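Substituent survey on the aryl ring of the shared core

The source may report more compounds than this note shows. Statements on the series, on what has been measured and on what is new or still open speak of the compounds shown alone.

Measured compounds in a functional assay on the whole organism for inhibition, with Rattus norvegicus as the target, at a dose of 30 mg/kg; on this read-out higher numbers stand for more inhibition at the one dose given (going by the name of the read-out) and lower numbers for less inhibition:
- compound 1, `c1ccc(-c2nc3cccnc3o2)cc1`: 55%
- compound 2, `COc1cccc(-c2nc3cccnc3o2)c1`: 0%
- compound 3, `Fc1cccc(-c2nc3cccnc3o2)c1`: 35%

Compound 3 stands second highest of the three numbers: compound 1 sits above it, a number 20 percentage points lower from compound 1 to compound 3 (beyond the scatter), and compound 2 sits below it, a number 35 percentage points higher from compound 2 to compound 3 (beyond the scatter). Compound 4, `Cc1cccc(-c2nc3cccnc3o2)c1`, has not yet been measured in this assay. It differs from compound 3 in one place: methyl in place of fluoro on an aromatic carbon.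

Going by the values given here, no measured step swaps fluoro for methyl, so the bearing steps are indirect. Replacing hydrogen with fluoro cost a modest amount, a number 20 percentage points lower from compound 1 to compound 3 (beyond the scatter); replacing hydrogen with methoxy cost a large amount, a number 55 percentage points lower from compound 1 to compound 2 (beyond the scatter). Both substitutions on this ring lowered inhibition relative to compound 1, and methyl, like fluoro, is a single heavy atom without donors or acceptors. A step for compound 4 that stays near compound 3, or moves slightly downward, is therefore expected, a number 5 percentage points lower from compound 3 to compound 4 (within the scatter). For compound 4 the estimate is 30%, within a range from 5% to 55%.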

Compound 4, a percentage reported as inhibition, in the whole organism at one dose (the size of the read-out at that dose, not a potency): 14%
Estimate against measurement, compound 4: 16 percentage points above, and the stated range covers the measured number.
By their numbers in this assay, from the lowest: compound 2; then compound 4; then compound 3; then compound 1.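

In this assay, fluoro and methyl on this aromatic carbon do not behave alike, although each is one heavy atom with no hydrogen-bond donors or acceptors (a number 21 percentage points lower from compound 3 to compound 4 (beyond the scatter)). Methyl also falls well short of the unsubstituted compound (a number 41 percentage points lower from compound 1 to compound 4 (beyond the scatter)), so all three groups at this position now sit below hydrogen, with no compound shown going against that. Methyl still retains more inhibition than methoxy (a number 14 percentage points higher from compound 2 to compound 4 (beyond the scatter)), but nothing available explains the order of these groups.

From the compounds shown here alone, whether any group at this position can match or exceed hydrogen stays open, for example an amine or a carboxylic acid. Also open, going by these compounds, is whether methyl, fluoro and methoxy would rank the same way elsewhere on this ring.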